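This account rests on a few compounds, and the source may have more. Where it says the series, first, only, none or still open, it means among the compounds named here.

The measured compounds and their values in a functional assay on KB 3-1 cells (Homo sapiens) for cytotoxicity, read by MTT assay, with a stated time of 68 h, tested at 5 uM; on this read-out higher numbers stand for weaker inhibition and lower numbers for stronger inhibition:

compound 1 `CC1(C)O[C@@H]2CC[C@](C)(O)[C@H](CC[C@@]34O[C@]3(C)[C@H](O)CC3C(CC[C@@]3(C)O)C4(C)C)[C@@]2(C)CC[C@H]1O`: 8.6 nM
compound 2 `CC1=CCC2C(CC[C@@]2(C)O)C(C)(C)C1CC[C@@H]1[C@@]2(C)CC[C@@H](O)C(C)(C)O[C@@H]2CC[C@]1(C)O`: 5 nM
compound 3 `CC1(C)O[C@@H]2CC[C@](C)(O)[C@H](CCC3C(C=O)=CCC4C(CC[C@@]4(C)O)C3(C)C)[C@@]2(C)CCC1=O`: 5.6 nM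

Among these three, compound 3 gives the second highest number in this assay. Its nearest neighbour is compound 2, whose number is slightly lower, and the furthest is compound 1, whose number is somewhat higher; both gaps lie within the usual scatter of this kind of measurement, so no order among the three can be read from the data, and none of them can be called the strongest or the weakest.

Compound 4 `CC1(C)O[C@@H]2CC[C@](C)(O)[C@H](CCC3C(CO)=CCC4C(CC[C@@]4(C)O)C3(C)C)[C@@]2(C)CCC1=O` has not yet been measured in this assay. It differs from compound 3 in one place: hydroxymethyl in place of formyl on a double-bonded ring carbon. Among the compounds with values here, no step between two measured compounds is available that would show what this particular change does. With nothing to lean on but the three values themselves, the author expects compound 4 to stay close to compound 3, with a modest move toward a higher number in this assay that may well turn out to lie within the scatter. The expected step is a 2.1-fold higher number from compound 3 to compound 4 (0.33 log units; beyond the scatter). For compound 4 the estimate in this assay is 12 nM, with a range from 5 nM to 35 nM.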

Compound 4, half-maximal inhibitory concentration: 6.3 nM
Compound 4: middle estimate off by 1.9-fold (0.28 log units), on the high side; low and high end bracket the measured number.
By their numbers in this assay, from the lowest: compounds 2, 3, 4 and 1 (each within the scatter of the next).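

In this assay, within the data shown here, the exchange of formyl for hydroxymethyl on a double-bonded ring carbon of the seven-membered ring gives a 1.1-fold higher number from compound 3 to compound 4 (0.05 log units; within the scatter), and this is the first direct reading of any single change. It shows that, on this core and in this read-out, the step from a group with no hydrogen-bond donor and a double bond outside aromatic rings to one with a hydrogen-bond donor and no such bond leaves compound 4 indistinguishable from compound 3. No measurement at hand bears on why the two compounds read alike.

On these data alone, a single pair cannot show how far this position tolerates change, so it remains open what a carboxylic acid, an aminomethyl group or a longer chain such as hydroxyethyl would do on the same ring carbon. Among these compounds, it also remains open whether the exchange of formyl for hydroxymethyl would read the same way on a core carrying other changes elsewhere, since the only step available comes from this one pair.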